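Branching the propyl chain on the shared core

A few compounds are considered here, and "the series" means these few. Any claim that something is new, unique, unknown or untested is made for them only; others in the source may bear on it.

Compound 1 `CCC/N=C(\NC#N)Nc1cccnc1` in a functional assay on the whole organism (blood, strain Wistar-Okamoto) with Rattus norvegicus as the target, with a stated time of 5 days (a lower number here means that less compound is needed, a higher number that more compound is needed for the effect), gives 20 mg/kg. Compound 2 `CCCC/N=C(\NC#N)Nc1cccnc1` in this assay gives 20 mg/kg. The one step measured so far, no change at the digits printed from compound 1 to compound 2 (within the scatter), so compound 1 stands level with compound 2 at the digits shown; nothing else in the series separates them.

Compound 3 `CC(C)C/N=C(\NC#N)Nc1cccnc1` differs from compound 1 by methyl in place of hydrogen on a saturated chain carbon bound to two saturated chain carbons. The step that bears on this change is no change at the digits printed from compound 1 to compound 2 (within the scatter), in which a methyl also entered the same chain and nothing moved beyond the scatter. That single step is all there is to go on, and it points to no shift. Compound 3 is therefore expected to sit level with compound 1, the step of no change at the digits printed from compound 1 to compound 3 (within the scatter) being estimated as none beyond the scatter. The estimate for compound 3 in this assay is 20 mg/kg, with a range from 10 mg/kg to 40 mg/kg.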

Compound 3, minimum effective dose: 20 mg/kg
For compound 3 middle estimate and measured number coincide at the digits printed; the range from low to high includes it.
By their numbers in this assay, from the lowest: compounds 1, 2 and 3 (each within the scatter of the next).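

Branching on the saturated chain carbon bound to two saturated chain carbons leaves this assay flat (here no change at the digits printed from compound 1 to compound 3 (within the scatter)), so a methyl at this place is tolerated as well as the added methyl that leads to compound 2. The shape of the chain also makes no difference among these compounds: isopropyl in place of propyl on the saturated chain carbon bound to a double-bonded nitrogen gives no separation (here no change at the digits printed from compound 2 to compound 3 (within the scatter)). No supporting measurement bears on this flat result.

As far as these compounds go, whether the flat reading persists with a longer chain such as hexyl or with a ring such as cyclohexyl on this nitrogen stays open. Also open, from the compounds shown here alone, is whether a terminal amine or a carboxylic acid on the chain would move the minimum effective dose.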